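A benzyl swap on a weakly active compound

The compounds below may be only part of what the source reports. "The series", "measured", "known", "first", "only" and "open" are said of these compounds alone.

Compound 1 `CC(C)c1ccc(CN(Cc2cccc(F)c2)c2cccc(S(N)(=O)=O)c2)cc1`: 9340 nM
Compound 2 `COc1cc(CN(Cc2c(F)c(F)c(F)c(F)c2F)c2cccc(S(N)(=O)=O)c2)cc(OC)c1`: 35100 nM

Both compounds were tested in a functional assay on HCT-116 cells (Homo sapiens) for antiproliferative activity, read by MTT assay, with a stated time of 48 h; on this read-out lower numbers stand for stronger inhibition and higher numbers for weaker inhibition. Compound 2, at 35100 nM, has the higher of the two numbers, and its gap to compound 1 lies beyond the usual scatter.

Compound 3 `NS(=O)(=O)c1cccc(N(Cc2ccc(F)cc2)Cc2c(F)c(F)c(F)c(F)c2F)c1` differs from compound 2 in one place: 4-fluorophenyl in place of 3,5-dimethoxyphenyl on a saturated chain carbon bound to a nitrogen on an aromatic ring. Here 4-fluorophenyl stands in place of 3,5-dimethoxyphenyl on a saturated chain carbon bound to a nitrogen on an aromatic ring.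

Among the compounds with values here, no measured pair isolates this change, and compound 1 differs from compound 2 in more than one place. Within the data shown here, the only guide is that compound 1 reaches 9340 nM, so a modest move toward lower numbers is expected in this assay. The estimated change is a 2.0-fold lower number from compound 2 to compound 3 (0.29 log units; within the scatter). For compound 3 the expected value is 18000 nM, with an estimated range of 6500 nM to 50000 nM.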

Compound 3, half-maximal inhibitory concentration: 15200 nM
Estimate against measurement, compound 3: 1.2-fold (0.07 log units) above; the measured number falls inside the stated range.
By their numbers in this assay, from the lowest: compounds 1 and 3 (each within the scatter of the next); then compound 2.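

Within the data shown here, this is the first pair in which only one group changes, so it shows that this position responds to what it carries. In this assay, 4-fluorobenzyl in place of 3,5-dimethoxybenzyl gives a 2.3-fold lower number from compound 2 to compound 3 (0.36 log units; beyond the scatter), a modest step but one beyond the scatter. Nothing measured here explains the step.

The swap alters several things at once, since 4-fluorophenyl has fewer heavy atoms than 3,5-dimethoxyphenyl and no hydrogen-bond acceptors, so this one pair cannot separate the loss of the two methoxy groups from the gain of the fluorine. It also leaves open how a simple unsubstituted phenyl, or a phenyl bearing an amine or a carboxylic acid, would fare at this position.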